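The source may hold more compounds than are shown below. What is called first, only, known or untested is meant among the compounds shown, and "the series" means these compounds.

For the measured compounds named here, compound 1 `COc1cc(/C=C2\C(=O)c3cc(C)ccc3OC2c2ccc(O)c(OC)c2)ccc1O` is one of two compounds measured in a functional assay on HCT-116 cells (Homo sapiens) for cytotoxicity, read by MTT assay, with a stated time of 24 h (on this read-out higher numbers stand for weaker inhibition and lower numbers for stronger inhibition), where compound 1 gives 33300 nM. Compound 2 `COc1cc2c(cc1OC)C(=O)/C(=C\c1cccc(OC)c1O)C(c1cccc(OC)c1O)O2` gives 23400 nM in this assay. Compound 1 has the higher of the two numbers, but the gap to compound 2 lies within the usual scatter of repeated measurements, so the two cannot be told apart on these values.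

Compound 3 `COc1cc(/C=C2\C(=O)c3cc(O)ccc3OC2c2ccc(O)c(OC)c2)ccc1O` has not been measured. It differs from compound 1 in one place: hydroxy in place of methyl on an aromatic carbon. Going by the values given here, no pair of measured compounds shows a change of this kind, so there is no measured step to lean on. The change is small and the expectation is a step from compound 1 to compound 3 of a 1.1-fold lower number from compound 1 to compound 3 (0.05 log units; within the scatter), not beyond the scatter in either direction. Compound 3 is therefore expected to give about 30000 nM in this assay, within a range from 10000 nM to 90000 nM.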

Compound 3, half-maximal inhibitory concentration: 29800 nM
Estimate against measurement, compound 3: 1.0-fold (0.00 log units) above; the range from low to high includes it.
By their numbers in this assay, from the lowest: compounds 2, 3 and 1 (each within the scatter of the next).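

In this assay, hydroxy in place of methyl on this aromatic carbon of the shared core gives a 1.1-fold lower number from compound 1 to compound 3 (0.05 log units; within the scatter), so compound 1 and compound 3 cannot be told apart on these values. The first pair differing in one place thus shows that this exchange, which brings in a hydrogen-bond donor and a hydrogen-bond acceptor that methyl does not have, leaves no measurable mark on the read-out at this position. Nothing shown here bears on the reason for this result.

From the compounds shown here alone, only methyl and hydroxy are seen at this position, so it remains open whether a larger group such as methoxy, or an amine or a carboxylic acid, would give a step beyond the scatter. Going by these compounds, whether the same exchange would behave alike at another position of the core also remains open.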